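From chloro to nitro on a shared core

The source may report more compounds than this note shows. Statements on the series, on what has been measured and on what is new or still open speak of the compounds shown alone.

Compound 1 `O=[N+]([O-])c1ccc(C(c2c[nH]c3ccc(Br)cc23)c2c[nH]c3ccc(Br)cc23)cc1` - 1500 nM
Compound 2 `N#Cc1ccc2[nH]cc(C(c3ccc(Cl)cc3)c3c[nH]c4ccc(C#N)cc34)c2c1` - > 100000 nM

In a functional assay on HeLa cells (Homo sapiens) for inhibition, read by MTT assay, with a stated time of 48 h (on this read-out lower numbers stand for stronger inhibition and higher numbers for weaker inhibition), compound 1 carries a 4-nitrophenyl group and gives 1500 nM as a measured number. Compound 2 has no measured number, only a limit of the assay at > 100000 nM in this series. Compound 3 `N#Cc1ccc2[nH]cc(C(c3ccc([N+](=O)[O-])cc3)c3c[nH]c4ccc(C#N)cc34)c2c1` differs from compound 2 by nitro in place of chloro on an aromatic carbon on the ring para to a large group. Among the compounds with values here, compound 1 at 1500 nM is the only measured compound with a nitro group, so stronger inhibition is expected. An estimated at least 6.6-fold lower number from compound 2 to compound 3 (0.82 log units; beyond the scatter) is expected in this assay toward lower numbers. For compound 3 the estimate is 15000 nM within an expected range from 2500 nM to 80000 nM on this read-out.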

Compound 3, half-maximal inhibitory concentration: > 100000 nM
Compound 3 ended at the assay's limit; the forecaster's own chance of this, stated with the estimate: 30%; middle value at least 6.6-fold (0.82 log units) away from the limit.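

Compound 2 and compound 3 both stand at a limit of the assay, so no step can be read between them: the limit of > 100000 nM in this assay, at which 2 of the 3 values shown sit.

The compounds shown leave open whether nitro in place of chloro changes inhibition on this core at all.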